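A few compounds are considered here, and "the series" means these few. Any claim that something is new, unique, unknown or untested is made for them only; others in the source may bear on it.

In an ADME assay on microsomes from liver (Homo sapiens) for metabolic stability, read by LC-MS, using NADPH, with a stated time of 30 min (a higher number here means that more of the compound is left, a lower number that less of the compound is left), three compounds sharing a core have been measured. Compound 1 `Cc1sc2ncnc(Oc3ccccc3F)c2c1C` gives < 5%, which is a limit of the assay and not a number. Compound 2 `CC(C)(C)c1cc2c(Oc3ccccc3F)ncnc2s1` gives 75%. Compound 3 `CC(C)(C)c1sc2ncnc(Oc3ccccc3F)c2c1-c1ccccc1` gives 94%, the higher of the two actual numbers.

Compound 4 `CC(C)(C)c1sc2ncnc(Oc3ccccc3F)c2c1-c1ccc(F)cc1` has not yet been measured. Its structure departs from that of compound 3 by one small change: fluoro in place of hydrogen on an aromatic carbon. This is fluoro in place of hydrogen on an aromatic carbon, which turns phenyl to 4-fluorophenyl.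

Among the measured compounds shown here, only one measured step bears on this change: a number 19 percentage points higher from compound 2 to compound 3 (beyond the scatter). It was a modest step, made by phenyl in place of hydrogen on an aromatic carbon. It shows that the added phenyl goes with more compound left, but it does not test fluoro on that phenyl. With compound 3 at 94%, the read-out also has little room left upward. No shift beyond the scatter is therefore expected in this assay, in either direction.

The expected step is a number 3 percentage points lower from compound 3 to compound 4 (within the scatter). The estimate for compound 4 is 91%, with an expected range from 78% to 99%.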

Compound 4, percent of the compound remaining: > 95%
Compound 4 gave a limit, no number (the forecaster's own chance of this, stated with the estimate: 3%); middle value at least 4 percentage points from the limit.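

In this assay compound 4 gives > 95%, which is a limit of the assay and not a number. The fluoro on the phenyl, para to a large group, is the first change shown on that ring, and it gives a number at least 1 percentage points higher from compound 3 to compound 4 (that floor lies within the scatter), so this read-out shows no loss of compound left on going from phenyl to 4-fluorophenyl, although that floor does not separate the two compounds. Measured against the compound with hydrogen at that place on the shared core, 4-fluorophenyl gives a number at least 20 percentage points higher from compound 2 to compound 4 (beyond the scatter), so the rise seen with phenyl remains when that ring carries fluoro.

How much more of compound 4 is left, if any, cannot be read, as its value stands at the end of the read-out: the limit of > 95% in this assay, at which 1 of the 4 values shown sits. Going by these compounds, whether a methoxy group, an amine or a carboxylic acid in place of the fluoro would leave as much compound after the same time stays open, and these compounds give no answer to it.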